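The compounds below may be only part of what the source reports. "The series", "measured", "known", "first", "only" and "open" are said of these compounds alone.

Measured in a functional assay on MDA-MB-231 cells (Homo sapiens) for antiproliferative activity, read by MTT assay, with a stated time of 48 h; a lower number here means a stronger inhibitor, a higher number a weaker inhibitor:
- Compound 1 `C/C(=C\CC/C(C)=C/CC[C@@H]1[C@@]2(C)CCC(=O)C(C)(C)[C@H]2CC[C@@]1(C)O)CC/C=C(\C)C(=O)OCc1cn(-c2ccccc2Br)nn1`: > 150000 nM, a limit
- Compound 2 `C/C(=C\CC/C(C)=C/CC[C@@H]1[C@@]2(C)CCC(=O)C(C)(C)[C@H]2CC[C@@]1(C)O)CC/C=C(\C)C(=O)OCc1cn(-c2cccc(F)c2)nn1`: 144000 nM
- Compound 3 `C/C(=C\CC/C(C)=C/CC[C@@H]1[C@@]2(C)CCC(=O)C(C)(C)[C@H]2CC[C@@]1(C)O)CC/C=C(\C)C(=O)OCc1cn(-c2cccc(C(F)(F)F)c2)nn1`: > 150000 nM, a limit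

Compound 3 has no exact number, only a limit: it sits at the limit of > 150000 nM in this assay, at which 2 of the 3 values shown sit. Compound 4 `C/C(=C\CC/C(C)=C/CC[C@@H]1[C@@]2(C)CCC(=O)C(C)(C)[C@H]2CC[C@@]1(C)O)CC/C=C(\C)C(=O)OCc1cn(-c2cccc(O)c2)nn1` carries hydroxy in place of trifluoromethyl on an aromatic carbon. The closest measured change, also on an aromatic carbon, is an at least 1.0-fold higher number from compound 2 to compound 3 (0.01 log units; that floor lies within the scatter). The other readable change is an at least 1.0-fold lower number from compound 1 to compound 2 (0.01 log units; that floor lies within the scatter). Within the data shown here, neither shows a size beyond the scatter, although no measured compound carries hydroxy. Among the measured compounds shown here, no large step is therefore expected in this assay, and compound 4 should stay close to that limit. The expected step is an at least 1.2-fold lower number from compound 3 to compound 4 (0.09 log units; that floor lies within the scatter). Compound 4 is estimated at 120000 nM, with an expected range from 50000 nM to 220000 nM.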

Compound 4, half-maximal inhibitory concentration: 139000 nM
Compound 4: the middle estimate sits 1.2-fold (0.06 log units) below what was measured, and the stated range covers the measured number.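

In this assay, among these compounds, hydroxy is the only group here with a hydrogen-bond donor, yet putting it at this place gives an at least 1.0-fold lower number from compound 3 to compound 4 (0.03 log units; that floor lies within the scatter), and replacing fluoro with it gives a 1.0-fold lower number from compound 2 to compound 4 (0.02 log units; within the scatter). Moving to 3-hydroxyphenyl from 2-bromophenyl on the aromatic nitrogen gives an at least 1.0-fold lower number from compound 1 to compound 4 (0.03 log units; that floor lies within the scatter), so none of these changes shows an effect beyond the scatter. Compound 1 and compound 3 each remain at a limit: the limit of > 150000 nM in this assay, at which 2 of the 4 values shown sit. As far as these compounds go, whether an amine or a carboxylic acid at this place would give a clearly lower number remains open.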